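One added hydroxy on compound 1

The source may hold more compounds than are shown below. What is called first, only, known or untested is meant among the compounds shown, and "the series" means these compounds.

Measured so far in a functional assay on MCF7 cells (Homo sapiens) for cytotoxicity, read by MTT assay, with a stated time of 72 h; on this read-out higher numbers stand for weaker inhibition and lower numbers for stronger inhibition:
Compound 1 `Cc1cc(/C=C/c2ccc(O)cc2)[nH]n1` gives 48100 nM
Compound 2 `COc1ccc(/C=C/c2cc(C)n[nH]2)cc1` gives 9700 nM

Compound 1 holds the higher of these two numbers, so it is the weaker of the pair. Compound 3 `Cc1cc(/C=C/c2ccc(O)c(O)c2)[nH]n1` differs from it by hydroxy in place of hydrogen on an aromatic carbon. For the measured compounds named here, only one measured step bears on this (a 5.0-fold lower number from compound 1 to compound 2 (0.70 log units; beyond the scatter)). That step is a different change, methyl in place of hydrogen on an oxygen on an aromatic ring, so it guides the size only loosely. A similarly modest move to a lower number in this assay is expected, though with little certainty. The estimated step is modest (a 2.4-fold lower number from compound 1 to compound 3 (0.38 log units; beyond the scatter)). Compound 3 is estimated at 20000 nM (expected range 6000 nM to 60000 nM).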

Compound 3, half-maximal inhibitory concentration: 23200 nM
For compound 3 the middle estimate is 1.2-fold (0.06 log units) below the measured one; measured number inside the range.
By their numbers in this assay, from the lowest: compound 2; then compound 3; then compound 1.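

Within this assay a hydroxy placed on the aromatic carbon ortho to the existing hydroxy group gives a 2.1-fold lower number from compound 1 to compound 3 (0.32 log units; beyond the scatter) and so shows that the number can also shift through a change on this ring carbon, not only through the change on the oxygen seen in compound 2. No measurement at hand explains this step. On these data alone, whether an amine or a chlorine atom on the same carbon would lower the number further stays open. So does the effect of a longer chain on the oxygen.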